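The source may hold more compounds than are shown below. What is called first, only, known or untested is meant among the compounds shown, and "the series" means these compounds.

The compounds here share one core and are compared in an assay on HL-60 cells for agonist activity at N-formyl peptide receptor 3 (Homo sapiens), read by calcium flux; on this read-out higher numbers stand for an effect only at larger amounts of compound and lower numbers for an effect already at smaller amounts. Compound 1 `COc1cccc(Cc2cc(C(C)C)nn(CC(=O)Nc3ccc(Br)cc3)c2=O)c1` gives a number in this assay: compound 1 reaches 17400 nM. Compound 2 `COc1cccc(Cc2cc(-c3ccccc3)nn(CC(=O)Nc3ccc(F)cc3)c2=O)c1` behaves differently. For compound 2 this assay reports only a limit, > 50000 nM. Compound 3 `COc1ccc(-c2cc(Cc3cccc(OC)c3)c(=O)n(CC(=O)Nc3ccc(F)cc3)n2)cc1` differs from compound 2 by a methoxy in place of hydrogen on an aromatic carbon. For compound 3 this assay again reports only a limit, > 50000 nM. The step that the two limits leave unreadable from compound 2 to compound 3 cannot be read because of the limit of > 50000 nM in this assay, at which 2 of the 3 values shown sit. Compound 3 thus stands at the edge of what this assay can report, alongside compound 2, while compound 1 alone gives a number.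

Compound 4 `COc1cccc(Cc2cc(-c3ccc(F)cc3)nn(CC(=O)Nc3ccc(F)cc3)c2=O)c1` differs from compound 3 by fluoro in place of methoxy on an aromatic carbon. Going by the values given here, no measured step covers this exchange: the only single-place step among the measured compounds is unreadable, and compound 1 and compound 2 differ in two places at once. Since the step that the two limits leave unreadable from compound 2 to compound 3 showed no readable movement, no movement beyond the scatter is expected for compound 4 either, and the likeliest outcome is that the assay again reports only a limit. For compound 4 the expected step is a step that the limit leaves unreadable from compound 3 to compound 4, small. For compound 4 the expected value is 60000 nM, within a range of 15000 nM to 250000 nM.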

Compound 4, half-maximal effective concentration: > 50000 nM
Compound 4 was reported as a limit (the forecaster's own chance of this, stated with the estimate: 80%); the middle value lies beyond the limit too.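

Compound 4, like compound 2 and compound 3, is reported only as a limit, so its steps from compound 2 and from compound 3 cannot be read and no new comparison arises: the limit of > 50000 nM in this assay, at which 3 of the 4 values shown sit.

Left open is which of the two places where compound 1 differs from compound 2 goes with a number in this assay rather than a limit.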